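Swapping a dichlorophenyl for a phenylethenyl group

The source may report more compounds than this note shows. Statements on the series, on what has been measured and on what is new or still open speak of the compounds shown alone.

In a functional assay on MCF7 cells (Homo sapiens) for cytotoxicity, read by sulforhodamine B assay, with a stated time of 48 h (on this read-out lower numbers stand for stronger inhibition and higher numbers for weaker inhibition), compound 1 `COc1ccc(C2C(C#N)=C(/N=C/c3ccccc3)Oc3nc(Nc4ccc(S(N)(=O)=O)cc4)sc32)cc1` gives 33600 nM. Compound 2 `COc1ccc(C2C(C#N)=C(/N=C/c3ccccc3Cl)Oc3nc(Nc4ccc(S(N)(=O)=O)cc4)sc32)cc1` gives 10300 nM in this assay, and compound 3 `COc1ccc(C2C(C#N)=C(/N=C/c3ccc(Cl)cc3Cl)Oc3nc(Nc4ccc(S(N)(=O)=O)cc4)sc32)cc1` gives 23500 nM, the second highest of the three numbers. The measured steps are a 3.3-fold lower number from compound 1 to compound 2 (0.51 log units; beyond the scatter), a 1.4-fold lower number from compound 1 to compound 3 (0.16 log units; within the scatter) and a 2.3-fold higher number from compound 2 to compound 3 (0.36 log units; beyond the scatter). Compound 4 `COc1ccc(C2C(C#N)=C(/N=C/C=C/c3ccccc3)Oc3nc(Nc4ccc(S(N)(=O)=O)cc4)sc32)cc1` is not yet measured; it differs from compound 3 by 2-phenylethenyl in place of 2,4-dichlorophenyl on a carbon with a double bond to nitrogen. For the measured compounds named here, no measured step replaces an aromatic ring at this position with a chain carrying a double bond, so only the small step of a 1.4-fold lower number from compound 1 to compound 3 (0.16 log units; within the scatter) offers a loose guide. A change no larger than the scatter is therefore expected, and compound 4 is estimated at 25000 nM, within 8000 nM to 70000 nM. This expectation amounts to a 1.1-fold higher number from compound 3 to compound 4 (0.03 log units; within the scatter).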

Compound 4, half-maximal inhibitory concentration: 28900 nM
Compound 4: the middle estimate sits 1.2-fold (0.06 log units) below what was measured; low and high end bracket the measured number.
By their numbers in this assay, from the lowest: compound 2; then compounds 3, 4 and 1 (each within the scatter of the next).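

With a 1.2-fold higher number from compound 3 to compound 4 (0.09 log units; within the scatter) and a 1.2-fold lower number from compound 1 to compound 4 (0.07 log units; within the scatter) the 2-phenylethenyl group, with its double bond outside the aromatic ring, sits level with the 2,4-dichlorophenyl and phenyl groups on this carbon with a double bond to nitrogen. Compound 2 still stands apart, and a 2.8-fold higher number from compound 2 to compound 4 (0.45 log units; beyond the scatter) shows that the new group does not match 2-chlorophenyl in this read-out. The compounds shown leave open what an amine, a carboxylic acid or a longer chain would do at this place. Nothing given here accounts for the separate standing of compound 2.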